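Carbonyl substituent variation on the shared core

This account rests on a few compounds, and the source may have more. Where it says the series, first, only, none or still open, it means among the compounds named here.

Measured so far:
Compound 1, `COc1ccc(CN(C(=O)C[Se]C#N)c2cc(OC)c(OC)c(OC)c2)cc1O`: in a functional assay on KYSE-450 cells (Homo sapiens) for inhibition, read by MTT assay, with a stated time of 48 h (a lower number here means a stronger inhibitor, a higher number a weaker inhibitor), compound 1 gives 280 nM.
Compound 2, `C=CC(=O)N(Cc1ccc(OC)c(O)c1)c1cc(OC)c(OC)c(OC)c1`: in this assay compound 2 gives 160 nM.

Compound 2 holds the lower of the two numbers, but the step of a 1.8-fold lower number from compound 1 to compound 2 (0.24 log units; within the scatter) lies within the scatter, so the two cannot be ordered. Compound 3, `COc1ccc(CN(C(=O)CO)c2cc(OC)c(OC)c(OC)c2)cc1O`, is not yet measured. It differs from compound 2 in one place: hydroxymethyl in place of vinyl on a carbonyl carbon. Within the data shown here, the only measured step that touches the same carbonyl carbon is a 1.8-fold lower number from compound 1 to compound 2 (0.24 log units; within the scatter), and it did not move the number beyond the scatter. Among the measured compounds shown here, no measured pair shows a hydrogen-bond donor entering at this position, so the expectation rests on that single step alone. The working expectation is therefore a step of about a 1.9-fold higher number from compound 2 to compound 3 (0.27 log units; within the scatter), with the direction uncertain. Compound 3 is estimated at 300 nM, within 120 nM to 800 nM.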

Compound 3, half-maximal inhibitory concentration: 370 nM
Estimate against measurement, compound 3: 1.2-fold (0.09 log units) below; the range from low to high includes it.
By their numbers in this assay, from the lowest: compounds 2, 1 and 3 (each within the scatter of the next, the first and the last beyond it).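

In this assay the carbonyl carbon now shows its first step beyond the scatter, as hydroxymethyl in place of vinyl gives a 2.3-fold higher number from compound 2 to compound 3 (0.36 log units; beyond the scatter) and this step is modest. Compound 3 and compound 1 cannot be ordered, since replacing the selenium-bearing group on the saturated chain carbon with one oxygen atom gives a 1.3-fold higher number from compound 1 to compound 3 (0.12 log units; within the scatter) and this step lies within the scatter. No evidence in hand explains the step from vinyl to hydroxymethyl.

This single pair cannot separate the loss of the double bond outside aromatic rings from the entry of the hydrogen-bond donor, and an ethyl group on the same carbonyl carbon would bear on that question. From the compounds shown here alone, how an amine, a carboxylic acid or a longer chain would read at this carbonyl carbon remains open.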